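Chloro for methoxy on the shared core

A few compounds are considered here, and "the series" means these few. Any claim that something is new, unique, unknown or untested is made for them only; others in the source may bear on it.

The shared core of compound 1 `COc1ccc(-c2cs/c(=N/NC(=O)CSc3nnnn3-c3ccccc3)n2-c2ccccc2)cc1`, compound 2 `COc1ccc(-c2cs/c(=N/NC(=O)CSc3nncn3C)n2-c2ccccc2)cc1` and compound 3 `COc1ccc(-c2cs/c(=N/NC(=O)CSc3nnc(C)s3)n2-c2ccccc2)cc1` is tested in an ADME assay on NIH3T3 cells (Mus musculus) for cytotoxicity, read by MTT assay, with a stated time of 24 h; a lower number here means a stronger inhibitor, a higher number a weaker inhibitor. Compound 1 gives 11.7 ug/mL, compound 2 gives 167 ug/mL and compound 3 gives 300 ug/mL. Compound 2 stands second highest of the three; its nearest neighbour is compound 3, at a 1.8-fold higher number from compound 2 to compound 3 (0.25 log units; within the scatter), and its furthest is compound 1, at a 14-fold higher number from compound 1 to compound 2 (1.15 log units; beyond the scatter). The other measured step, a 26-fold higher number from compound 1 to compound 3 (1.41 log units; beyond the scatter), is also large.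

Compound 4 `Cn1cnnc1SCC(=O)N/N=c1/scc(-c2ccc(Cl)cc2)n1-c1ccccc1` differs from compound 2 in one place: chloro in place of methoxy on an aromatic carbon, on an aromatic carbon of a six-membered aromatic ring of carbon only. All three measured steps change the group on the sulfur and leave this ring untouched, so none bears on this change; nothing in the series shows what exchanging the methoxy for chloro does in this assay. The expectation is therefore a step within the scatter, a 1.0-fold lower number from compound 2 to compound 4 (0.02 log units; within the scatter), in no particular direction. Compound 4 is estimated at 160 ug/mL, with a range from 60 ug/mL to 400 ug/mL.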

Compound 4, half-maximal inhibitory concentration: 51.7 ug/mL
For compound 4 the middle estimate is 3.1-fold (0.49 log units) above the measured one, outside the stated range (below it).
By their numbers in this assay, from the lowest: compound 1; then compound 4; then compounds 2 and 3 (each within the scatter of the next).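

Within the data shown here, exchanging 4-methoxyphenyl for 4-chlorophenyl on the shared core gives a 3.2-fold lower number from compound 2 to compound 4 (0.51 log units; beyond the scatter) in this assay as a modest step, so this ring position, untouched by the earlier steps, does move the read-out. That step is smaller than the change on the sulfur seen in a 14-fold higher number from compound 1 to compound 2 (1.15 log units; beyond the scatter) and so far rests on a single pair. No measurement available bears on why the number falls.

Whether the same exchange gives a similar step with 1-phenyl-1H-tetrazol-5-yl or 5-methyl-1,3,4-thiadiazol-2-yl on the sulfur remains open, since the compounds shown pair it only with 4-methyl-4H-1,2,4-triazol-3-yl. Also open, from the compounds shown here alone, is how other groups at this position, such as fluoro, an amine or a carboxylic acid, would read in this assay.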